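Bromophenyl Position Shift in a Cytotoxicity Series

The compounds below may be only part of what the source reports. "The series", "measured", "known", "first", "only" and "open" are said of these compounds alone.

Measured so far:
compound 1, `COc1ccccc1Nc1nc(-c2cccc(F)c2)nc2ccc(F)cc12`: > 50000 nM
compound 2, `Fc1cccc(-c2nc(Nc3ccc(Br)cc3)c3cc(F)ccc3n2)c1`: > 50000 nM

In a functional assay on U-937 cells (Homo sapiens) for cytotoxicity, read by MTT assay, with a stated time of 48 h (a higher number here means a weaker inhibitor, a lower number a stronger inhibitor), compound 1 returns only a limit, > 50000 nM. In this assay compound 2 likewise returns only a limit, > 50000 nM. For the measured compounds named here, the single measured step, a step that the two limits leave unreadable from compound 1 to compound 2, therefore cannot be read in size or direction. Going by the values given here, compound 2 thus stands at the limit of this assay, as does its one neighbour, because of the limit of > 50000 nM in this assay, at which 2 of the 2 values shown sit.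

Compound 3, `Fc1cccc(-c2nc(Nc3ccccc3Br)c3cc(F)ccc3n2)c1`, differs from compound 2 by 2-bromophenyl in place of 4-bromophenyl on a nitrogen on an aromatic ring. No measured step bears on this change; the only step shown, from compound 1 to compound 2, is unreadable, so it gives no expected size or direction for compound 3 in this assay.

The expectation for compound 3 is simply that it stays at the limit of this assay, an estimated value of 50000 nM with a range from 20000 nM to 100000 nM. The expected step of a number no higher from compound 2 to compound 3 (the limit leaves the size open) is accordingly estimated as none beyond the scatter.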

Compound 3, half-maximal inhibitory concentration: > 50000 nM
Compound 3: no number, only a limit; the forecaster's own chance of this, stated with the estimate: 80%; the middle value lies on the limit itself.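

For the compounds shown here, no step among compound 1, compound 2 and compound 3 can be read, since all three sit at one limit: the limit of > 50000 nM in this assay, at which 3 of the 3 values shown sit.

Whether 2-bromophenyl, 4-bromophenyl or 2-methoxyphenyl makes any difference in this assay stays open, as none of these compounds gives a number there.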